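Notes on a ring exchange in the series

The source may report more compounds than this note shows. Statements on the series, on what has been measured and on what is new or still open speak of the compounds shown alone.

Of the compounds shown here, two have numbers so far in a functional assay on CNE-2 cells (Homo sapiens) for antiproliferative activity, read by sulforhodamine B assay, with a stated time of 48 h; a higher number here means a weaker inhibitor, a lower number a stronger inhibitor. Compound 1 `COc1cccc(/C=C/C(=O)/C=C(O)/C=C/c2cccc(OC)c2OC)c1OC` gives 12800 nM, and compound 2 `COc1cc(C=C(C(=O)/C=C/c2cccc(OC)c2OC)C(=O)/C=C/c2cccc(OC)c2OC)ccc1O` gives 280 nM. Compound 2 thus holds the lower number of the two, marking it as the stronger inhibitor by a margin beyond the usual scatter. The two structures differ in more than one place, so the pair isolates no single change.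

Next in line is compound 3 `COc1cc(OC)c(C=C(C(=O)/C=C/c2cccc(OC)c2OC)C(=O)/C=C/c2cccc(OC)c2OC)c(OC)c1`, which carries 2,4,6-trimethoxyphenyl in place of 4-hydroxy-3-methoxyphenyl on a double-bonded chain carbon bound to a double-bonded chain carbon. The rest of compound 2 stays unchanged. Among the compounds with values here, no measured step isolates this exchange, so the expectation rests only on compound 2 at 280 nM and remains wide. A modest move towards a weaker inhibitor is expected, and the estimated shift is a 2.1-fold higher number from compound 2 to compound 3 (0.33 log units; beyond the scatter). For compound 3 the estimated value is 600 nM, with an expected range from 180 nM to 2000 nM.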

Compound 3, half-maximal inhibitory concentration: 630 nM
Beside the measured number, compound 3's estimate is 1.1-fold (0.02 log units) below it; the range from low to high includes it.
By their numbers in this assay, from the lowest: compound 2; then compound 3; then compound 1.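

In this assay, within the data shown here, the exchange of 4-hydroxy-3-methoxyphenyl for 2,4,6-trimethoxyphenyl on a double-bonded chain carbon bound to a double-bonded chain carbon gives a 2.3-fold higher number from compound 2 to compound 3 (0.35 log units; beyond the scatter) and is the first single-place step. The position thus accepts a group with 12 heavy atoms and 0 hydrogen-bond donors in place of one with 9 heavy atoms and 1 hydrogen-bond donor at a modest cost, with compound 3 still at 630 nM in this assay. No measurement at hand bears on the reason for this step.

Open is which part of the exchange carries the step, since the two groups differ in the hydroxyl, in the number of methoxy groups and in where these stand, and no compound shown alters one of these alone. Also open, as far as these compounds go, is how this position responds to a group of another kind, such as an amine or a carboxylic acid on the aromatic ring, and whether the step holds outside this assay at all.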